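A few compounds are considered here, and "the series" means these few. Any claim that something is new, unique, unknown or untested is made for them only; others in the source may bear on it.

Among the compounds with values here, compound 2 `CCCC(=O)OCSc1ccccc1C(=O)NCCCCNC(C)=O` gives 17.4 uM in an ADME assay on CEM-SS cells (Homo sapiens) for cytotoxicity, read by XTT assay, with a stated time of 6 days (on this read-out higher numbers stand for lower toxicity in this test and lower numbers for higher toxicity in this test), and is the only compound here with one single number. Compound 1 `CCCC(=O)OCSc1ccccc1C(=O)NCCC(N)=O` gives > 100 uM as a limit of the assay and not a number. Compound 3 `CCCC(=O)OCSc1ccccc1C(=O)N[C@H]1CCC[C@@H]1C(N)=O` gives 31.2 uM; 43.3 uM (2 entries) from two entries that agree within the usual scatter.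

The next case is compound 4 `CCCC(=O)OCSc1ccccc1C(=O)N[C@@H]1CCC[C@H]1C(N)=O`, where 2-carbamoylcyclopentyl replaces 4-acetamidobutyl on an amide-type nitrogen. The counted difference is 2-carbamoylcyclopentyl in place of 4-acetamidobutyl on an amide-type nitrogen and it brings in a ring with 2 defined stereocentres. Within the data shown here, the only measured step, an at least 5.7-fold lower number from compound 1 to compound 2 (0.75 log units; beyond the scatter), concerns a different change and starts from a limit, so it shows only that one swap of this kind can move the number beyond the scatter.

Closer guidance comes from the several entries of compound 3 in this assay, 31.2 uM; 43.3 uM (2 entries), since compound 3 also carries a 2-carbamoylcyclopentyl group, with its two stereocentres set the opposite way. How much that setting matters has not been measured, so the estimate stays wide. The expected change is a 2.1-fold higher number from compound 2 to compound 4 (0.32 log units; beyond the scatter) in this assay, a small move towards a higher number, close to the size of the scatter. Compound 4 is estimated at 36 uM, with an expected range from 15 uM to 85 uM in this test.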

Compound 4, half-maximal toxic concentration: 43.7 uM
Compound 4: the middle estimate sits 1.2-fold (0.08 log units) below what was measured; the range from low to high includes it.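

In this assay, 2-carbamoylcyclopentyl in place of 4-acetamidobutyl on the amide-type nitrogen gives a 2.5-fold higher number from compound 2 to compound 4 (0.40 log units; beyond the scatter), so this position responds even when the incoming and outgoing groups match in heavy atoms, hydrogen-bond donors and hydrogen-bond acceptors. Compound 1 gives only a limit of the assay and not a number, so the step that replaces its 2-carbamoylethyl with 2-carbamoylcyclopentyl is a bound and not an exact size: an at least 2.2-fold lower number from compound 1 to compound 4 (0.35 log units; beyond the scatter). Compound 3 gives 31.2 uM; 43.3 uM (2 entries) and compound 4 gives 43.7 uM, so these printed values show no clear separation when the two stereocentres are set the opposite way, a comparison that rests on this: the fact that compounds 3 and 4 differ only in the configuration as drawn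

The step from 4-acetamidobutyl to 2-carbamoylcyclopentyl changes both the ring and the end group at once, so the compounds shown leave open how much of the change belongs to each. They also leave open whether an amine or a carboxylic acid in place of the carbamoyl group, or a six-membered carbon ring in place of the cyclopentyl ring, would shift the number in this assay.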